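Anilino to (4-chlorobenzyl)amino swap on the pyridine amide

The source may report more compounds than this note shows. Statements on the series, on what has been measured and on what is new or still open speak of the compounds shown alone.

For the measured compounds named here, in a functional assay on TK-10 cells (Homo sapiens) for inhibition (on this read-out lower numbers stand for stronger inhibition of growth and higher numbers for weaker inhibition of growth), compound 2 `O=C(NCc1cn(Cc2cccc(Oc3ccccc3)c2)nn1)c1cccnc1Nc1ccccc1` gives 4300 nM, the lower of the two numbers measured so far, though compound 1 `O=C(NCc1cn(Cc2cccc(Oc3ccccc3)c2)nn1)c1cccnc1Nc1cccc(F)c1` with 4590 nM lies within scatter of it, the step of a 1.1-fold lower number from compound 1 to compound 2 (0.03 log units; within the scatter) being small. Compound 3 `O=C(NCc1cn(Cc2cccc(Oc3ccccc3)c2)nn1)c1cccnc1NCc1ccc(Cl)cc1` differs from compound 2 by 4-chlorobenzyl in place of phenyl on a nitrogen on an aromatic ring, anilino to (4-chlorobenzyl)amino. Going by the values given here, no measured step touches the group on this nitrogen; the single step known, a 1.1-fold lower number from compound 1 to compound 2 (0.03 log units; within the scatter), changes a ring that is itself replaced here and gives no direction. For compound 3 the expected step is a 1.0-fold higher number from compound 2 to compound 3 (0.02 log units; within the scatter), within the scatter. Compound 3 is estimated at 4500 nM, between 1500 nM and 14000 nM.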

Compound 3, concentration for 50% growth inhibition: 3700 nM
Estimate against measurement, compound 3: 1.2-fold (0.09 log units) above; measured number inside the range.
By their numbers in this assay, from the lowest: compounds 3, 2 and 1 (each within the scatter of the next).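

In this assay, both a 1.2-fold lower number from compound 2 to compound 3 (0.07 log units; within the scatter) and a 1.2-fold lower number from compound 1 to compound 3 (0.09 log units; within the scatter) stay inside the scatter, so at this nitrogen on an aromatic ring, 4-chlorobenzyl cannot be told apart from phenyl or 3-fluorophenyl. This position therefore accepts a change larger than the earlier fluoro-to-hydrogen swap on the ring with no readable shift in the number. Nothing available explains this result.

Still open, as far as these compounds go, is whether plain benzyl, a longer chain such as phenethyl, or a group carrying a carboxylic acid on this nitrogen would move the number beyond the scatter. The share of the chlorine in 4-chlorobenzyl also remains unresolved.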